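The source may report more compounds than this note shows. Statements on the series, on what has been measured and on what is new or still open speak of the compounds shown alone.

The account centers on an ADME assay on microsomes from liver (Homo sapiens) for metabolic stability; a higher number here means faster removal of the compound, a lower number slower removal. Of the compounds shown here, three have been measured so far. Compound 1 `CC(C)n1nc(-c2ccnc3[nH]c(C4CCN(CC(=O)N(C)C)CC4)cc23)ccc1=O` gives 13 uL/min in this assay. Compound 3 `Cc1nc2ccc(-c3ccnc4[nH]c(C5CCN(CC(=O)N(C)C)CC5)cc34)cc2n1C(C)C` gives 63 uL/min in this assay, a higher number whose gap from compound 1 lies beyond the usual scatter. Compound 2 `COc1cc(F)ccc1-c1ccnc2[nH]c(C3CCN(C(C)=O)CC3)cc12` reports only a limit of this assay, < 3 uL/min, and not a number, as the evidence notes (the limit of < 3 uL/min in this assay, at which 1 of the 3 values shown sits). Among the two numbers shown, compound 1 stands lowest, with compound 3 the only other number to set beside it.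

Compound 4 `CN(C)C(=O)CN1CCC(c2cc3c(-c4ccc(=O)n(C)c4)ccnc3[nH]2)CC1` has not been measured in this assay. It differs from compound 1 at one site: a group of 8 heavy atoms (6 carbon, 1 nitrogen, 1 oxygen; one six-membered aromatic ring with 1 hetero atom) in place of a group of 10 heavy atoms (7 carbon, 2 nitrogen, 1 oxygen; one six-membered aromatic ring with 2 hetero atoms), on an aromatic carbon. The entering group sits on an aromatic carbon of a six-membered aromatic ring with 1 nitrogen, part of a fused or bridged system of two rings, opposite the ring nitrogen. Among the compounds with values here, no measured pair shares this one change, so the expectation rests on compound 1 alone. Compound 4 is expected to give about 10 uL/min in this assay, with a range from 4 uL/min to 25 uL/min. The step of a 1.3-fold lower number from compound 1 to compound 4 (0.11 log units; within the scatter) that this estimate implies is expected to be small, within the scatter, in no clear direction.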

Compound 4, intrinsic clearance in a liver preparation (reported as CLH), per the amount of preparation that the assay uses: < 3 uL/min
Compound 4 ended at the assay's limit (the forecaster's own chance of this, stated with the estimate: 15%); middle value at least 3.3-fold (0.52 log units) away from the limit.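

On an aromatic carbon opposite the ring nitrogen, replacing the group of 10 heavy atoms with the group of 8 heavy atoms gives an at least 4.3-fold lower number from compound 1 to compound 4 (0.63 log units; beyond the scatter) in this assay, the first step shown in which only one place differs. Within the data shown here, the group at this place therefore moves the read-out by more than the usual scatter, which the earlier compounds, differing in more than one place, could not show. The result for compound 4 is a limit and not a number, so the step fixes only a smallest size and leaves its full size unknown, and values at this limit cannot be ordered among themselves: the limit of < 3 uL/min in this assay, at which 2 of the 4 values shown sit.

The entering group differs from the leaving group both in the hetero atoms of its six-membered aromatic ring and in its count of heavy atoms, and the compounds shown do not separate these two differences. Where a group bearing an amine, a carboxylic acid or a longer chain at this place would fall in this assay also remains open.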